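The source may report more compounds than this note shows. Statements on the series, on what has been measured and on what is new or still open speak of the compounds shown alone.

Compound 3 `C#CCN(C)CCCCOc1ccc(C(C)=O)cc1OC` is the weakest of the three measured compounds: in an assay on BTI cells for inhibition of Amine oxidase [flavin-containing] B (Homo sapiens), read by fluorescence and Amplex Red, with a stated time of 15 min (a lower number here means a stronger inhibitor, a higher number a weaker inhibitor), compound 3 gives 1150 nM. Compound 1 `C#CCN(C)CCCCOc1ccc(C(C)=O)cc1` gives 56.5 nM in this assay, and compound 2 `C#CCN(C)CCCCCCOc1ccc(C(C)=O)cc1` gives 20.4 nM in this assay. The step with methoxy in place of hydrogen on an aromatic carbon is a 20-fold higher number from compound 1 to compound 3 (1.31 log units; beyond the scatter). The chain lengthening of a 2.8-fold lower number from compound 1 to compound 2 (0.44 log units; beyond the scatter) works the other way. Compound 4 `C#CCN(C)CCCCCOc1ccc(C(C)=O)cc1OC` differs from compound 3 in a single place: (methyl(propargyl)amino)methyl in place of methyl(propargyl)amino on a saturated chain carbon, four bonds along the chain from an oxygen on an aromatic ring. The measured step that bears on this is a 2.8-fold lower number from compound 1 to compound 2 (0.44 log units; beyond the scatter), which covered two added chain carbons rather than one. With only one carbon added, a smaller lowering in this assay is expected for compound 4, perhaps not clearly beyond the scatter. The estimated step of a 1.6-fold lower number from compound 3 to compound 4 (0.22 log units; within the scatter) is therefore a modest improvement. Compound 4 is expected to give about 700 nM in this assay, with a range from 300 nM to 1600 nM.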

Compound 4, half-maximal inhibitory concentration: 6520 nM
The estimate for compound 4 lay 9.3-fold (0.97 log units) below the measured number; measured number above the stated range.
By their numbers in this assay, from the lowest: compound 2; then compound 1; then compound 3; then compound 4.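

With methoxy on the aromatic carbon, adding to the chain at this position gives a higher number in this assay (a 5.7-fold higher number from compound 3 to compound 4 (0.75 log units; beyond the scatter)). Going by these compounds alone, the only earlier chain step (a 2.8-fold lower number from compound 1 to compound 2 (0.44 log units; beyond the scatter)) ran the opposite way, though on the core without methoxy and with a longer addition, so these two pairs show no single direction for chain extension at this position. Nothing available here accounts for this reversal.

The compounds shown leave open whether the higher number follows from the methoxy group, from the added length, or from the two together, since the two chain steps differ in both. The 2-(methyl(propargyl)amino)ethyl chain on the methoxy-bearing core would separate these readings, and an ethoxy or chloro group in place of methoxy also remains untested among these compounds.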